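The source may report more compounds than this note shows. Statements on the series, on what has been measured and on what is new or still open speak of the compounds shown alone.

Measured compounds:
Compound 1 `CN1CCN(CCCS(=O)(=O)c2ccc3nc(NC(=O)NC(=O)c4cc(-n5cccc5)ccc4Cl)sc3c2)CC1` gives 0.15 nM in an assay on HEK293 cells for displacement of a labelled ligand from growth hormone secretagogue receptor type 1 (Homo sapiens), with a stated time of 60 min; on this read-out higher numbers stand for weaker inhibition and lower numbers for stronger inhibition.
Compound 2 `Cc1ccn(-c2ccc(Cl)c(C(=O)NC(=O)Nc3nc4ccc(S(=O)(=O)CCCN5CCN(C)CC5)cc4s3)c2)n1` gives 0.53 nM.
Compound 3 `CN1CCN(CCCS(=O)(=O)c2ccc3nc(NC(=O)NC(=O)c4cc5c(ccn5C)cc4Cl)sc3c2)CC1` gives 0.57 nM.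

Compound 3 has the highest number of the three, though its gap to compound 2 lies within the scatter, and only compound 1 sits clearly below it. Compound 4 `CN1CCN(CCCS(=O)(=O)c2ccc3nc(NC(=O)NC(=O)c4cc(-n5cccn5)ccc4Cl)sc3c2)CC1` is not yet measured. It differs from compound 3 in one place: 2-chloro-5-(1H-pyrazol-1-yl)phenyl in place of 5-chloro-1-methyl-1H-indol-6-yl on a carbonyl carbon. Among the compounds with values here, two measured steps bear on this change. The step of a 3.8-fold higher number from compound 1 to compound 3 (0.58 log units; beyond the scatter) is reversed here, which on its own would point toward a lower number. The step of a 3.5-fold higher number from compound 1 to compound 2 (0.55 log units; beyond the scatter) shows that a pyrazol-1-yl ring in that position raises the number again. Taken together, compound 4 is expected to land modestly below compound 3, with a 1.9-fold lower number from compound 3 to compound 4 (0.28 log units; within the scatter); the estimate for compound 4 is 0.3 nM, within the range 0.12 nM to 0.8 nM.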

Compound 4, half-maximal inhibitory concentration: 0.67 nM
Compound 4: the middle estimate sits 2.2-fold (0.35 log units) below what was measured; the range from low to high includes it.
By their numbers in this assay, from the lowest: compound 1; then compounds 2, 3 and 4 (each within the scatter of the next).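

In this assay the 2-chloro-5-(1H-pyrazol-1-yl)phenyl group in place of 5-chloro-1-methyl-1H-indol-6-yl on a carbonyl carbon gives a 1.2-fold higher number from compound 3 to compound 4 (0.07 log units; within the scatter) and so does not separate the two groups. Hydrogen in place of the methyl on the pyrazole ring gives a 1.3-fold higher number from compound 2 to compound 4 (0.10 log units; within the scatter) and leaves that methyl without a readable effect. 1H-pyrazol-1-yl in place of 1H-pyrrol-1-yl gives a 4.5-fold higher number from compound 1 to compound 4 (0.65 log units; beyond the scatter) and shows that the gap to compound 1 persists without the methyl. Nothing given here explains that gap. From the compounds shown here alone, whether an amine or a carboxylic acid on the 1H-pyrazol-1-yl ring would shift the number remains open.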